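This account rests on a few compounds, and the source may have more. Where it says the series, first, only, none or still open, it means among the compounds named here.

In a functional assay on A549 cells (Homo sapiens) for cytotoxicity, read by MTT assay, with a stated time of 72 h (on this read-out lower numbers stand for stronger inhibition and higher numbers for weaker inhibition), compound 1 (`CNC(=O)c1cc(Oc2ccc(NC(=O)c3cc(-c4ccc(C)cc4)ncn3)cc2)ccn1`) gives > 100000 nM, which is a limit and not a number. Compound 2 (`CNC(=O)c1cc(Oc2ccc(NC(=O)c3cc(-c4ccc(Br)cc4)ncn3)cc2)ccn1`), with bromo in place of methyl, gives > 100000 nM, also a limit. Both thus stand at the limit of > 100000 nM in this assay, at which 2 of the 3 values shown sit. Compound 3 (`CNC(=O)c1cc(Oc2ccc(NC(=O)c3cc(-c4ccccc4)ncn3)cc2)ccn1`), with hydrogen there instead, gives 27100 nM. The measured steps are an at least 3.6-fold lower number from compound 1 to compound 3 (0.56 log units; beyond the scatter) and an at least 3.6-fold lower number from compound 2 to compound 3 (0.56 log units; beyond the scatter). Compound 4 (`CNC(=O)c1cc(Oc2ccc(NC(=O)c3cc(-c4ccc(C)cc4)ncn3)cc2F)ccn1`) keeps the methyl of compound 1 and differs by fluoro in place of hydrogen on an aromatic carbon, the fluoro sitting ortho to a (2-(methylcarbamoyl)pyridin-4-yl)oxy group. Going by the values given here, none of the measured steps touches that place, so no step beyond the scatter is expected. The estimated step is a number no higher from compound 1 to compound 4 (the limit leaves the size open). Compound 4 is expected at 100000 nM, with an estimated range of 40000 nM to 200000 nM.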

Compound 4, half-maximal inhibitory concentration: 13200 nM
Beside the measured number, compound 4's estimate is 7.6-fold (0.88 log units) above it, outside the stated range (below it).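

Earlier steps touched only the place of the methyl, whereas this one shows that the ring ortho to a (2-(methylcarbamoyl)pyridin-4-yl)oxy group also matters in this assay: fluoro in place of hydrogen there gives an at least 7.5-fold lower number from compound 1 to compound 4 (0.87 log units; beyond the scatter). With this change, a compound keeping the methyl reads as a number and no longer as a limit. The full size of the step stays unknown because compound 1 stands at a limit: the limit of > 100000 nM in this assay, at which 2 of the 4 values shown sit.

On these data alone, whether fluoro acts the same way with bromo or hydrogen in place of the methyl remains open. So does the outcome with chloro or methoxy in place of the fluoro.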